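The source may report more compounds than this note shows. Statements on the series, on what has been measured and on what is new or still open speak of the compounds shown alone.

Working notes on the trimethoxyphenyl-benzimidazole series in a functional assay on MCF7 cells (Homo sapiens) for antiproliferative activity, read by MTT assay, with a stated time of 72 h; a higher number here means a weaker inhibitor, a lower number a stronger inhibitor.

Three compounds are measured. Compound 1 `COc1cc(-n2cnc3ccc(-c4cccc(F)c4)cc32)cc(OC)c1OC` gives 2350 nM; compound 2 `COc1cccc(-c2ccc3ncn(-c4cc(OC)c(OC)c(OC)c4)c3c2)c1` gives 1610 nM; compound 3 `COc1cc(-n2cnc3ccc(-c4ccc(Cl)cc4Cl)cc32)cc(OC)c1OC` gives 5420 nM. Compound 3 stands at the highest of the three numbers: the step of a 2.3-fold higher number from compound 1 to compound 3 (0.36 log units; beyond the scatter) and the step of a 3.4-fold higher number from compound 2 to compound 3 (0.53 log units; beyond the scatter) both run beyond the scatter, while the step of a 1.5-fold lower number from compound 1 to compound 2 (0.16 log units; within the scatter) lies within it.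

Compound 4 `COc1cc(-n2cnc3ccc(-c4ccc(C(C)=O)cc4)cc32)cc(OC)c1OC` is not yet measured. It differs from compound 3 in one place: 4-acetylphenyl in place of 2,4-dichlorophenyl on an aromatic carbon. Going by the values given here, no measured compound carries an acetyl substituent on this ring, so the change is only partly covered. Among the compounds with values here, what bears on it is that the two steps toward 2,4-dichlorophenyl, a 2.3-fold higher number from compound 1 to compound 3 (0.36 log units; beyond the scatter) and a 3.4-fold higher number from compound 2 to compound 3 (0.53 log units; beyond the scatter), were both modest increases; leaving that group again is therefore expected to give a modest decrease in this assay, back toward the numbers of compound 1 and compound 2, with wide uncertainty because the entering 4-acetylphenyl has no precedent in the set. The step expected is a 2.5-fold lower number from compound 3 to compound 4 (0.39 log units; beyond the scatter). For compound 4 the estimate in this assay is 2200 nM, within a range from 800 nM to 6000 nM.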

Compound 4, half-maximal inhibitory concentration: 1540 nM
Beside the measured number, compound 4's estimate is 1.4-fold (0.15 log units) above it; measured number inside the range.
By their numbers in this assay, from the lowest: compounds 4, 2 and 1 (each within the scatter of the next); then compound 3.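

In this assay, the position on the fused ring system tolerates a larger substituted phenyl: a 3.5-fold lower number from compound 3 to compound 4 (0.55 log units; beyond the scatter) is a modest step beyond the scatter, and it shows that the high number of compound 3 does not extend to every change of the aryl group here. The other two steps, a 1.0-fold lower number from compound 2 to compound 4 (0.02 log units; within the scatter) and a 1.5-fold lower number from compound 1 to compound 4 (0.18 log units; within the scatter), both lie within the scatter, so 4-acetylphenyl, 3-methoxyphenyl and 3-fluorophenyl cannot be told apart at this position, and compound 3 with its 2,4-dichlorophenyl is the only one of the four set apart from the rest. No measurement of any other kind accompanies these numbers, so the data give no explanation for that separation.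

The compounds shown leave open whether a single chlorine on the phenyl ring would keep the number of compound 3 or fall with compounds 1, 2 and 4. They also leave open whether an amine or a carboxylic acid in place of the acetyl would stay within this same band.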